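This account rests on a few compounds, and the source may have more. Where it says the series, first, only, none or still open, it means among the compounds named here.

Compound 1 `C=C1C[C@]23C[C@@]1(O)CC[C@H]2c1ccc(O)c(C)c1[C@@H]3Cn1cc(-c2ccccn2)nn1`: > 20000 nM in a functional assay on SMMC-7721 cells (Homo sapiens) for cytotoxicity, read by MTT assay, with a stated time of 4 days; on this read-out higher numbers stand for weaker inhibition and lower numbers for stronger inhibition
Compound 2 `C=C1C[C@]23C[C@@]1(O)CC[C@H]2c1ccc(O)c(C)c1[C@@H]3Cn1cc(-c2ccc(OC)cc2)nn1`: > 20000 nM
Compound 3 `C=C1C[C@]23C[C@@]1(O)CC[C@H]2c1cc(Br)c(O)c(C)c1[C@@H]3Cn1cc(-c2ccc(Cl)cc2)nn1`: 19100 nM.

Compound 1 gives a value that is a limit of the assay, not a number. Compound 2 gives a value that is likewise a limit. Compound 3 alone gives a number, and it stands close to the limit of > 20000 nM in this assay, at which 2 of the 3 values shown sit. Going by the values given here, the one measured single-point step, a step that the two limits leave unreadable from compound 1 to compound 2, cannot be sized. Compound 4 `C=C1C[C@]23C[C@@]1(O)CC[C@H]2c1ccc(O)c(C)c1[C@@H]3Cn1cc(-c2ccc(Cl)cc2)nn1` differs from compound 3 by hydrogen in place of bromo on an aromatic carbon. Among the compounds with values here, no measured step touches this position; nothing shows how far the loss of the bromo moves the read-out in this assay. The step of a 1.3-fold higher number from compound 3 to compound 4 (0.12 log units; within the scatter) is expected to stay within the usual scatter. Compound 4 is therefore estimated near 25000 nM, between 10000 nM and 60000 nM, with a real chance that only a limit is reported.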

Compound 4, half-maximal inhibitory concentration: > 20000 nM
Compound 4 gave a limit, no number (the forecaster's own chance of this, stated with the estimate: 60%); the middle value is on the limit's open side.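

In this assay, a measured step now reaches the aromatic carbon ortho to the hydroxy group: hydrogen in place of bromo gives an at least 1.0-fold higher number from compound 3 to compound 4 (0.01 log units; that floor lies within the scatter). Compound 4 gives a limit, so this step has only a floor, which lies within the scatter, and the steps to compound 4 from compound 1 and compound 2 cannot be read. Nearly the whole set now rests at one edge of the read-out: the limit of > 20000 nM in this assay, at which 3 of the 4 values shown sit.

As far as these compounds go, whether an amine or a carboxylic acid on this carbon would give a number clearly away from that limit stays open. From the compounds shown here alone, how far the bromo itself moves the read-out also stays open.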